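Replacing 4-chloro-3-fluorophenyl with oxan-4-yl

This account rests on a few compounds, and the source may have more. Where it says the series, first, only, none or still open, it means among the compounds named here.

Compound 1 `COc1nc(-c2ccsc2)ccc1[C@@H](c1ccccc1)[C@@](O)(CCN(C)C)c1cccc2ccccc12`: > 64 ug/mL, a limit
Compound 2 `COc1nc(-c2ccc(Cl)c(F)c2)ccc1[C@@H](c1ccccc1)[C@@](O)(CCN(C)C)c1cccc2ccccc12`: > 64 ug/mL, a limit

In a toxicity assay on HeLa cells (Homo sapiens) for cytotoxicity (a lower number here means that less compound is tolerated, a higher number that more compound is tolerated), compound 2 gives > 64 ug/mL, which is a limit. Compound 1 gives > 64 ug/mL, also a limit. For the measured compounds named here, the series so far therefore stands at the limit of > 64 ug/mL in this assay, at which 2 of the 2 values shown sit, and neither compound has a number.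

Compound 3 `COc1nc(C2CCOCC2)ccc1[C@@H](c1ccccc1)[C@@](O)(CCN(C)C)c1cccc2ccccc12` carries a new group on the shared core: oxan-4-yl in place of 4-chloro-3-fluorophenyl on an aromatic carbon. Going by the values given here, the one measured step at this aromatic carbon is a step that the two limits leave unreadable from compound 1 to compound 2, so it offers no size to carry over. No step beyond the scatter is expected in this assay, and another reading at the limit is the likeliest outcome. The expected change is a number no higher from compound 2 to compound 3 (the limit leaves the size open). For compound 3 the estimate is 64 ug/mL, with an expected range of 30 ug/mL to 130 ug/mL.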

Compound 3, half-maximal cytotoxic concentration: 22.5 ug/mL
The estimate for compound 3 lay 2.8-fold (0.45 log units) above the measured number; the measured number lies below the stated range.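

In this assay the change to oxan-4-yl at this aromatic carbon gives an at least 2.8-fold lower number from compound 2 to compound 3 (0.45 log units; beyond the scatter) and thiophen-3-yl gives way to the same group with an at least 2.8-fold lower number from compound 1 to compound 3 (0.45 log units; beyond the scatter) as its step. For the compounds shown here, this is the first sign that the group at this position can move the read-out, which the unreadable step between the two aromatic groups could not show. Both new steps stay open-ended because compound 1 and compound 2 each sit at a limit and have no number: the limit of > 64 ug/mL in this assay, at which 2 of the 3 values shown sit.

On these data alone, it remains open whether the fall follows the loss of the aromatic ring or the entry of the ring oxygen; cyclohexyl, a non-aromatic ring of carbon only, would separate the two. As far as these compounds go, how far compound 1 and compound 2 truly lie from compound 3 also remains open.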